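The compounds below may be only part of what the source reports. "The series", "measured", "known", "first", "only" and "open" are said of these compounds alone.

Among the compounds with values here, compound 2 `c1ccc(Cc2nnc(-c3c[nH]c4ccccc34)o2)cc1` gives 934000 nM in a functional assay on MIA PaCa-2 cells (Homo sapiens) for cytotoxicity, read by MTT assay (on this read-out higher numbers stand for weaker inhibition and lower numbers for stronger inhibition), the only plain number among the values shown. Compound 1 `c1ccc(-c2nnc(-c3c[nH]c4ccccc34)o2)cc1` is reported only as a limit of the assay, > 1000000 nM, as the limit of > 1000000 nM in this assay, at which 1 of the 2 values shown sits, marks. Within the data shown here, the single measured step, an at least 1.0-fold lower number from compound 1 to compound 2 (0.02 log units; that floor lies within the scatter), lay within the scatter. Compound 3 `c1ccc2c(-c3nnc(-c4ccncc4)o3)c[nH]c2c1` carries the change (pyridin-4-yl in place of benzyl on an aromatic carbon). Among the measured compounds shown here, no measured step covers this exchange, and the only step seen was flat, so the estimated step of a 1.0-fold lower number from compound 2 to compound 3 (0.02 log units; within the scatter) is expected to stay within the scatter. Compound 3 is therefore estimated at 900000 nM, in a range from 300000 nM to 3000000 nM.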

Compound 3, half-maximal inhibitory concentration: 1600 nM
Compound 3: middle estimate off by 560-fold (2.75 log units), on the high side, outside the stated range (below it).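

At this position on the five-membered aromatic ring, pyridin-4-yl is the first group shown to move this assay beyond the scatter, with a 580-fold lower number from compound 2 to compound 3 (2.77 log units; beyond the scatter). Set against phenyl, the same group gives an at least 620-fold lower number from compound 1 to compound 3 (2.79 log units; beyond the scatter), although the exchange of phenyl for benzyl had stayed within the scatter. Compound 1 remains a limit of the assay, and this second step is only a floor: the limit of > 1000000 nM in this assay, at which 1 of the 3 values shown sits.

As far as these compounds go, what pyridin-3-yl or a phenyl bearing an amine would give at this position stays open. The compounds shown also leave open whether the ring nitrogen itself accounts for the drop or only its place in the ring.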